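Dropping the Hydroxyethyl Arm: Expected Cytotoxicity of Compound 4

The compounds below may be only part of what the source reports. "The series", "measured", "known", "first", "only" and "open" are said of these compounds alone.

Measured so far:
compound 1, `C[C@H](c1c[nH]c2ccccc12)[C@@H]1SC(NCCO)=NC1=O`: > 100 ug/mL
compound 2, `C/N=C1/S[C@@H]([C@H](C)c2c[nH]c3ccccc23)C(=O)N1C`: 12 ug/mL
compound 3, `CNC1=NC(=O)C(Cc2c[nH]c3ccccc23)S1`: > 100 ug/mL

Three compounds built on the same core were tested in an ADME assay on HeLa cells (Homo sapiens) for cytotoxicity, read by neutral red uptake; on this read-out higher numbers stand for lower toxicity in this test and lower numbers for higher toxicity in this test. Compound 1 gives only a limit in this assay, > 100 ug/mL, and not a number. Compound 3 also gives only a limit, > 100 ug/mL. Compound 2 gives a number, 12 ug/mL. So compound 1 does not stand at a fixed point on a scale; it sits at the limit of > 100 ug/mL in this assay, at which 2 of the 3 values shown sit, and only compound 2 lies clearly inside the measured range.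

Compound 4, `CNC1=NC(=O)[C@H]([C@H](C)c2c[nH]c3ccccc23)S1`, differs from compound 1 in one place: hydrogen in place of hydroxymethyl on a saturated chain carbon bound to an amine nitrogen. Going by the values given here, no pair of measured compounds differs in exactly this way, so the size of the step cannot be read from the data. Compound 4 is expected to stay at the limit of this assay because of the limit of > 100 ug/mL in this assay, at which 2 of the 3 values shown sit. The step from compound 1 to compound 4 is therefore expected to be none beyond the usual scatter, a number no higher from compound 1 to compound 4 (the limit leaves the size open). The estimate for compound 4 is 100 ug/mL, between 40 ug/mL and 200 ug/mL.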

Compound 4, minimum cytotoxic concentration: 30 ug/mL
Estimate against measurement, compound 4: 3.3-fold (0.52 log units) above; the measured number lies below the stated range.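

In this assay compound 1 gives > 100 ug/mL, which is a limit of the assay and not a number. Cutting the 2-hydroxyethyl arm on the amine nitrogen back to methyl brings an at least 3.3-fold lower number from compound 1 to compound 4 (0.52 log units; beyond the scatter), so this position is not a silent one: within this pair, the arm with the hydroxyl goes with lower toxicity in this test, and removing the hydroxymethyl piece alone gives a change beyond the usual scatter. As far as these compounds go, the step can only be given as a minimum, and its full size stays unknown: the limit of > 100 ug/mL in this assay, at which 2 of the 4 values shown sit.

An ethyl group in this place would help separate the part played by the oxygen from that of chain length. From the compounds shown here alone, whether a longer chain, or an amine or a carboxylic acid at the end of the arm, would move the number up or down also stays open.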